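This account rests on a few compounds, and the source may have more. Where it says the series, first, only, none or still open, it means among the compounds named here.

In a functional assay on T98G cells (Homo sapiens) for cytotoxicity, read by MTT assay, with a stated time of 48 h (a higher number here means a weaker inhibitor, a lower number a stronger inhibitor), compound 1 `C/C(=N/NC(=S)Nc1ccccc1)c1ccccn1` gives 6.81 nM and compound 2 `C/C(=N\NC(=S)Nc1ccc(F)cc1)c1ccccn1` gives 17 nM as the higher number of the two, a gap beyond the scatter. Compound 3 `C/C(=N/NC(=S)Nc1ccc(F)cc1)c1ccccn1` differs from compound 2 by the two compounds have the same atoms and bonds and differ only in configuration as drawn: 1 of 1 stereo elements differ; a double bond is drawn E in compound 2 and Z in compound 3 and keeps the same atoms and bonds. Within the data shown here, no measured pair isolates this kind of change, so this assay offers no direct guide and no shift beyond the scatter is expected. The expected change is a 1.2-fold lower number from compound 2 to compound 3 (0.08 log units; within the scatter) and stays within that scatter. For compound 3 the estimated value is 14 nM with an expected range from 5 nM to 40 nM as a working figure.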

Compound 3, half-maximal inhibitory concentration: 17 nM
Beside the measured number, compound 3's estimate is 1.2-fold (0.08 log units) below it; measured number inside the range.
By their numbers in this assay, from the lowest: compound 1; then compounds 2 and 3 (each within the scatter of the next).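

In this assay, reversing the double bond as drawn gives no change at the digits printed from compound 2 to compound 3 (within the scatter), so this change does not separate the two forms at this position. With the double bond drawn the same way on both sides, fluoro in place of hydrogen on an aromatic carbon gives a 2.5-fold higher number from compound 1 to compound 3 (0.40 log units; beyond the scatter). The first comparison therefore rests on a single difference: the fact that compounds 2 and 3 differ only in the configuration as drawn

As far as these compounds go, whether chloro, methoxy or an amine on that aromatic carbon would give a number like that of fluoro stays open. Also open, from the compounds shown here alone, is whether the configuration as drawn persists in the cells during the assay.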